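Fixing the stereocentres of compound 1

This account rests on a few compounds, and the source may have more. Where it says the series, first, only, none or still open, it means among the compounds named here.

Compound 1 `O=C(CNC1CC1c1cc(F)cc(F)c1OCc1cccnc1F)N1CCC2(CCNC2)CC1`: 73%
Compound 2 `O=C(CNC1CC1c1cc(F)cc(F)c1OCc1cccnc1F)N1CCC(N2CC3CCC(C2)O3)CC1`: 0%
Compound 3 `O=C(CNC1CC1c1cc(F)cc(F)c1OCc1cccnc1F)N1CCC2(CCCN2)CC1`: 42%

In an ADME assay on microsomes from liver (Mus musculus) for metabolic stability, read by mass spectrometry, using NADPH, with a stated time of 60 min (a lower number here means that less of the compound is left, a higher number that more of the compound is left), compound 1 stands highest of the three measured compounds. Compound 3 lies nearest to it, and the furthest is compound 2. The next compound, compound 4 `O=C(CN[C@H]1C[C@@H]1c1cc(F)cc(F)c1OCc1cccnc1F)N1CCC2(CCNC2)CC1`, differs from compound 1 only in how it is drawn: the two compounds have the same atoms and bonds; at least one stereo element is drawn with a configuration in one of them and without one in the other: 2 of 2 stereo elements differ; a stereocentre at a saturated ring carbon is drawn without a configuration in compound 1 and S in compound 4; a stereocentre at a saturated ring carbon is drawn without a configuration in compound 1 and R in compound 4. The atoms and bonds stay the same, and a configuration, S at one saturated ring carbon and R at the other, replaces the undrawn stereocentres.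

Among the compounds with values here, the only measured step, a number 31 percentage points lower from compound 1 to compound 3 (beyond the scatter), is large, but it exchanges the group on the carbonyl carbon, and compound 4 keeps the group of compound 1. Within the data shown here, no measured pair shows what a change of configuration does, so that step gives no direct guide to size or direction. With no evidence for a shift, no step beyond the scatter is expected. The expected change is a number 3 percentage points lower from compound 1 to compound 4 (within the scatter). The uncertainty stays wide, since the data cannot show how the two stereocentres matter. Compound 4 is estimated at 70%, with an expected range from 50% to 88%.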

Compound 4, percent of the compound remaining: 62%
Compound 4: middle estimate off by 8 percentage points, on the high side; low and high end bracket the measured number.
By their numbers in this assay, from the lowest: compound 2; then compound 3; then compound 4; then compound 1.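

In this assay, within the data shown here, there is a number 11 percentage points lower from compound 1 to compound 4 (beyond the scatter), the first measured step that leaves the atoms and bonds untouched, so the way the two saturated ring carbons are drawn is tied to a difference beyond the scatter. This step is smaller than a number 31 percentage points lower from compound 1 to compound 3 (beyond the scatter), and compound 4, with S at one ring carbon and R at the other, gives 62%, well clear of compound 2 at 0%. The structures offer only one difference to set against this gap: the fact that one of compounds 1 and 4 is drawn with a defined configuration and the other without, at the place where they differ

The compounds shown leave open how other configurations at these two ring carbons would read, and whether the same step would appear with the group of compound 3 on the carbonyl carbon. They also leave open how an open-chain amine on the carbonyl carbon would stand in this assay.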